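This account rests on a few compounds, and the source may have more. Where it says the series, first, only, none or still open, it means among the compounds named here.

In a functional assay on HCT-116 cells (Homo sapiens) for cytotoxicity, read by MTT assay, with a stated time of 72 h (a higher number here means a weaker inhibitor, a lower number a stronger inhibitor), compound 1 (`O=C1c2c[n+]([O-])c3ccccc3c2C(=O)c2c1c1ccccc1n2Cc1cn(CC(O)CO)nn1`) gives 250 nM and compound 2 (`O=C1c2c[n+]([O-])c3ccccc3c2C(=O)c2c1c1ccccc1n2CCCCN1CCNCC1`) gives 700 nM, the higher of the two numbers. Compound 3 (`CN1CCN(CCCn2c3c(c4ccccc42)C(=O)c2c[n+]([O-])c4ccccc4c2C3=O)CC1`) differs from compound 2 by one change: 4-methylpiperazin-1-yl in place of (piperazin-1-yl)methyl on a saturated chain carbon, three bonds along the chain from an aromatic nitrogen. Within the data shown here, the only measured step, a 2.8-fold higher number from compound 1 to compound 2 (0.45 log units; beyond the scatter), is modest and swaps a quite different group, so it bears only loosely on this change. No step beyond the scatter is therefore expected in this assay, in either direction. The estimated step is a 1.2-fold lower number from compound 2 to compound 3 (0.07 log units; within the scatter). For compound 3 the expected value is 600 nM, with an estimated range of 220 nM to 1600 nM.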

Compound 3, half-maximal inhibitory concentration: 560 nM
Beside the measured number, compound 3's estimate is 1.1-fold (0.03 log units) above it, and the stated range covers the measured number.
By their numbers in this assay, from the lowest: compound 1; then compounds 3 and 2 (each within the scatter of the next).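

In this assay, exchanging 4-(piperazin-1-yl)butyl for 3-(4-methylpiperazin-1-yl)propyl, the same atoms joined differently with hydrogen-bond donors going from 1 to 0, gives a 1.3-fold lower number from compound 2 to compound 3 (0.10 log units; within the scatter) and so leaves the number effectively unmoved. The 1-(2,3-dihydroxypropyl)-1H-1,2,3-triazol-4-yl side chain still stands apart, with a 2.2-fold higher number from compound 1 to compound 3 (0.35 log units; beyond the scatter) remaining modest but real. Nothing available explains either result.

Still open, on these data alone, is whether a morpholine or a dimethylamino group on the same propyl chain, or a 4-methylpiperazine on a shorter ethyl chain, would keep the number in this range.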